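The source may hold more compounds than are shown below. What is called first, only, known or untested is meant among the compounds shown, and "the series" means these compounds.

Working notes on the amide side chain of the shared core.

Compound 1 `CC(C)(N)CCC(=O)N[C@@H]1CCc2ccccc2N(Cc2ccc(-c3ccccc3-c3nn[nH]n3)cc2)C1=O` gives 3 uM in a functional assay on cells (Pituitary gland cell) with growth hormone secretagogue receptor type 1 (Rattus norvegicus) as the target; a lower number here means that less compound is needed, a higher number that more compound is needed for the effect. Compound 2 `NCCC(=O)N[C@@H]1CCc2ccccc2N(Cc2ccc(-c3ccccc3-c3nn[nH]n3)cc2)C1=O` gives 2 uM in this assay, and the change between them reads a 1.5-fold lower number from compound 1 to compound 2 (0.18 log units; within the scatter). Compound 3 `CC(C)(CC(=O)N[C@@H]1CCc2ccccc2N(Cc2ccc(-c3ccccc3-c3nn[nH]n3)cc2)C1=O)NCCO` gives 30 uM, the highest of the three numbers; the steps onto it read a 10-fold higher number from compound 1 to compound 3 (1.00 log units; beyond the scatter) and a 15-fold higher number from compound 2 to compound 3 (1.18 log units; beyond the scatter), and both replace a primary amine with a (2-hydroxyethyl)amino group.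

Compound 4 `CC(C)(N)CC(=O)N[C@@H]1CCc2ccccc2N(Cc2ccc(-c3ccccc3-c3nn[nH]n3)cc2)C1=O` differs from compound 3 by hydrogen in place of 2-hydroxyethyl on an amine nitrogen, so the chain keeps the 1-methylethyl branching of compound 3 while the nitrogen returns to a primary amine, as in compound 1 and compound 2. Among the compounds with values here, no step between compound 4 and either of those is on hand; their numbers sit close to each other.

Since the two measured steps onto compound 3 raised the number by a similar amount, the reverse move is expected to lower it by about as much, giving a 10-fold lower number from compound 3 to compound 4 (1.00 log units; beyond the scatter). Compound 4 is therefore estimated at 3 uM in this assay, within 1 uM to 10 uM.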

Compound 4, concentration for half-maximal effect: 0.06 uM
Compound 4: middle estimate off by 50-fold (1.70 log units), on the high side, outside the stated range (below it).
By their numbers in this assay, from the lowest: compound 4; then compounds 2 and 1 (each within the scatter of the next); then compound 3.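

The primary amine alone does not account for the low number: removing the 2-hydroxyethyl group gives a 500-fold lower number from compound 3 to compound 4 (2.70 log units; beyond the scatter) in this assay, yet compound 1 and compound 2 also carry a primary amine and remain far higher. Here the 1-amino-1-methylethyl group is set apart from both neighbours, with a 33-fold lower number from compound 2 to compound 4 (1.52 log units; beyond the scatter) against the aminomethyl group and a 50-fold lower number from compound 1 to compound 4 (1.70 log units; beyond the scatter) against the 2-amino-2-methylpropyl group, so neither the two methyl groups nor the shorter chain suffices alone among these compounds. No supporting measurement bears on why this combination stands out.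

The compounds shown leave open whether a single methyl branch on the same chain carbon would retain the low number. They also leave open whether a methylamino group would behave like the amino group of compound 4 or the (2-hydroxyethyl)amino group of compound 3.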